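The source may hold more compounds than are shown below. What is called first, only, known or untested is meant among the compounds shown, and "the series" means these compounds.

Working notes on the series.

Compound 1 `Cc1cc(Nc2nc(NCc3ccc(F)cc3F)nc3ccccc23)n[nH]1` in an assay for inhibition of high affinity nerve growth factor receptor (Homo sapiens), read by HTRF, with a stated time of 30 min, in the presence of a further agent that is not named here (on this read-out higher numbers stand for weaker inhibition and lower numbers for stronger inhibition), gives 200 nM, the highest of the three numbers recorded so far. Compound 2 `Cc1cc(Nc2nc(NCc3c(F)cccc3F)nc3ccccc23)n[nH]1` in this assay gives 160 nM, and compound 3 `Cc1cc(Nc2nc(NCc3ccc(F)c(F)c3)nc3ccccc23)n[nH]1` in this assay gives 74 nM. The step of a 1.3-fold lower number from compound 1 to compound 2 (0.10 log units; within the scatter) stays within the scatter, whereas a 2.7-fold lower number from compound 1 to compound 3 (0.43 log units; beyond the scatter) and a 2.2-fold lower number from compound 2 to compound 3 (0.33 log units; beyond the scatter) are modest steps beyond it. All three measured steps move the fluorines around the benzyl ring; the shared core is unchanged throughout.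

Compound 4 `Cc1ccc2nc(NCc3ccc(F)cc3F)nc(Nc3cc(C)[nH]n3)c2c1` differs from compound 1 by methyl in place of hydrogen on an aromatic carbon on the six-membered carbon-only ring of the fused core. For the measured compounds named here, none of the measured steps touches this ring, so no recorded step bears directly on the change; the benzyl-ring steps only show that small changes move the read-out by modest amounts at most. With nothing measured on the core, compound 4 is expected to stay close to compound 1 in this assay, and the expected step of no change at the digits printed from compound 1 to compound 4 (within the scatter) is not expected to exceed the scatter. For compound 4 the estimated value in this assay is 200 nM, with a range from 70 nM to 600 nM.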

Compound 4, half-maximal inhibitory concentration: 110 nM
The estimate for compound 4 lay 1.8-fold (0.26 log units) above the measured number, and the stated range covers the measured number.
By their numbers in this assay, from the lowest: compounds 3, 4, 2 and 1 (each within the scatter of the next, the first and the last beyond it).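

In this assay, methyl in place of hydrogen gives a 1.8-fold lower number from compound 1 to compound 4 (0.26 log units; within the scatter). For the compounds shown here, this is the first reading at an aromatic carbon of the six-membered aromatic ring of carbon only, since the earlier steps moved only the fluorines on the benzyl ring, and it shows that this position takes a methyl with the read-out staying within the scatter of compound 1. No measurement shown gives a reason for this reading.

Still open, on these data alone, is whether a larger or differently built group on this aromatic carbon, such as methoxy, a primary amine, a carboxylic acid or a longer alkyl chain, would also stay within the scatter of compound 1, or whether it would move the number beyond it. Going by these compounds alone, also open are the other aromatic carbons of that ring, and whether the methyl would behave in the same way alongside the 3,4-difluorophenyl group of compound 3, since the single step here was read only with the 2,4-difluorophenyl group.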